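A few compounds are considered here, and "the series" means these few. Any claim that something is new, unique, unknown or untested is made for them only; others in the source may bear on it.

Working notes on the series. Compound 3 `O=C1C[C@H](OCc2cc(-c3ccc(Cl)cc3)no2)[C@H]2CO[C@@H]1O2` gives 14500 nM in a functional assay on HT-29 cells (Homo sapiens) for cytotoxicity, read by MTT assay, with a stated time of 48 h; a higher number here means a weaker inhibitor, a lower number a stronger inhibitor; compound 1 `O=C1C[C@H](OCc2cn(-c3ccc([N+](=O)[O-])cc3)nn2)[C@H]2CO[C@@H]1O2` gives 18300 nM and compound 2 `O=C1C[C@H](OCc2cc(-c3ccc([N+](=O)[O-])cc3)no2)[C@H]2CO[C@@H]1O2` gives 19800 nM. Compound 3 stands at the lowest of the three numbers, but its gaps to compound 1 and to compound 2 are both within the scatter, so the three compounds stand together rather than apart. For the measured compounds named here, the one single-point step among them, a 1.4-fold lower number from compound 2 to compound 3 (0.14 log units; within the scatter), is likewise within the scatter. Compound 4 `O=C1C[C@H](OCc2cc(-c3ccc(Cl)o3)no2)[C@H]2CO[C@@H]1O2` is not yet measured; it differs from compound 3 by 5-chlorofuran-2-yl in place of 4-chlorophenyl on an aromatic carbon. Going by the values given here, no measured step touches this change: the only step recorded concerns a different substituent and was itself small. The numbers therefore give no ground for expecting a shift beyond the scatter in either direction in this assay for compound 4. For compound 4 the expected value is 15000 nM, with a range from 7000 nM to 32000 nM. The step of a 1.0-fold higher number from compound 3 to compound 4 (0.01 log units; within the scatter) is the estimate, amounting to no change beyond the scatter.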

Compound 4, half-maximal inhibitory concentration: 10100 nM
The estimate for compound 4 lay 1.5-fold (0.17 log units) above the measured number; measured number inside the range.
By their numbers in this assay, from the lowest: compounds 4, 3, 1 and 2 (each within the scatter of the next).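

In this assay, the aromatic carbon next to the ring nitrogen carries either 4-chlorophenyl or 5-chlorofuran-2-yl, and a 1.4-fold lower number from compound 3 to compound 4 (0.16 log units; within the scatter) shows that replacing the six-membered aromatic ring of carbon only with a five-membered aromatic ring with 1 hetero atom gives no change beyond the scatter. The earlier step changed only the substituent on the aromatic ring, from nitro to chloro, whereas this one changes the ring itself and adds a hydrogen-bond acceptor, so the position accommodates both ring types without a shift beyond the scatter. No available evidence bears on this result.

Still open, going by these compounds, is whether a group without an aromatic ring, such as an amine, a carboxylic acid or a longer chain, would hold the number at this position. Also open, on these data alone, is whether 5-chlorofuran-2-yl would behave the same without its chlorine.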